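The source may report more compounds than this note shows. Statements on the series, on what has been measured and on what is new or still open speak of the compounds shown alone.

Measured so far in a physicochemical assay for lipophilicity, read by HPLC; a higher number here means a more lipophilic compound, a lower number a more polar compound:
- compound 1 `CCn1c(-c2cnc(C)nc2)nc2c(N[C@H]3CCN(C(=O)N4CC(OC)C4)C3)ncnc21`: 0.7
- compound 2 `CCn1c(-c2ccc(C(F)(F)F)nc2)nc2c(O[C@H]3CCN(C(=O)[C@H]4C[C@@H](OC)C4)C3)ncnc21`: 2.2
- compound 3 `CCn1c(-c2cnc(C)nc2)nc2c(O[C@H]3CCN(C(=O)C4CC4)C3)ncnc21`: 1

In this assay, compound 1 gives 0.7. For the measured compounds named here, that number cannot be told apart from the one for compound 3, at 1, given the usual scatter of repeated measurements. Compound 2, at 2.2, stands clearly higher than compound 1.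

The next compound to be measured is compound 4 `CCn1c(-c2cnc(C)nc2)nc2c(N[C@H]3CCN(C(=O)C4CC4)C3)ncnc21`. It differs from compound 1 in one place: cyclopropyl in place of 3-methoxyazetidin-1-yl on a carbonyl carbon. Put simply, cyclopropyl takes the place of 3-methoxyazetidin-1-yl on a carbonyl carbon.

Going by the values given here, no measured pair of compounds isolates this change, so any forecast is only loosely supported. The nearest guide is compound 3, which also carries cyclopropyl on a carbonyl carbon and gives 1, although it differs from compound 4 elsewhere in its structure.

On that basis, the expected step of a number 0.20 log units higher from compound 1 to compound 4 (within the scatter) is small and upward, and not expected to go beyond the scatter. The estimate for compound 4 is 0.9, with an expected range of 0.5 to 1.3.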

Compound 4, distribution coefficient: 0.8
Compound 4: middle estimate off by 0.10 log units, on the high side; measured number inside the range.
By their numbers in this assay, from the lowest: compounds 1, 4 and 3 (each within the scatter of the next); then compound 2.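

On the carbonyl carbon whose other neighbour is an amide-type nitrogen in a ring, this assay now gives its first direct reading of a single change, with cyclopropyl in place of 3-methoxyazetidin-1-yl giving a step of a number 0.10 log units higher from compound 1 to compound 4 (within the scatter) for this swap. Here 3-methoxyazetidin-1-yl, with 6 heavy atoms including a nitrogen and an oxygen, and cyclopropyl, with 3 carbon atoms, cannot be told apart by this assay. No measurement at hand accounts for this result.

On these data alone, whether other groups on this carbonyl carbon would also read alike remains open, for instance a dimethylamino group or a longer chain such as n-butyl. As far as these compounds go, it is also open whether this same swap would give a similar step on a different core, such as that of compound 3.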